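Replacing Methyl with Fluoro in Compound 3

This account rests on a few compounds, and the source may have more. Where it says the series, first, only, none or still open, it means among the compounds named here.

In an ADME assay for permeability, using PAMPA, at pH 4 (a lower number here means that the compound crosses the layer more slowly, a higher number that the compound crosses the layer faster), compound 1 (`Cc1[nH]c2ccccc2c(=O)c1C1CCCCC1`) gives 260 10^-6 cm/s and compound 2 (`Cc1[nH]c2ccccc2c(=O)c1Cc1ccccc1`) gives 110 10^-6 cm/s on the same scale. Compound 3 (`Cc1ccc2[nH]c(C)c(Br)c(=O)c2c1`) stands lowest of the three at 26.4 10^-6 cm/s and lies beyond the scatter from both others, closest to compound 2 and furthest from compound 1. Compound 4 (`Cc1[nH]c2ccc(F)cc2c(=O)c1Br`) has yet to be measured in this assay and differs from compound 3 in one place (fluoro in place of methyl on an aromatic carbon), with fluoro in place of methyl on an aromatic carbon. No measured pair among these compounds shows this exchange, so the expectation rests only on the structural change and on compound 3 at 26.4 10^-6 cm/s as its starting point. The expected step is a 1.5-fold lower number from compound 3 to compound 4 (0.17 log units; within the scatter) in this estimate, a small downward move that is not expected to go beyond the scatter. For compound 4 the estimated value is 18 10^-6 cm/s with an expected range from 7 10^-6 cm/s to 45 10^-6 cm/s once it is measured.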

Compound 4, apparent permeability: 16.2 10^-6 cm/s
The estimate for compound 4 lay 1.1-fold (0.05 log units) above the measured number; low and high end bracket the measured number.
By their numbers in this assay, from the lowest: compounds 4 and 3 (each within the scatter of the next); then compound 2; then compound 1.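

In this assay, for the compounds shown here, the exchange of methyl for fluoro gives the first measured step at this position: a 1.6-fold lower number from compound 3 to compound 4 (0.21 log units; within the scatter). On this aromatic carbon, meta to a fused ring and para to a fused ring, the two groups therefore cannot be told apart in this read-out, and a single pair is all that supports this reading. No other measurement here bears on this result.

Going by these compounds alone, whether an amine, a carboxylic acid or a longer chain on the same carbon would move the number beyond the scatter remains open, since methyl and fluoro are the only groups compared at this place. On these data alone, it is also open whether fluoro in place of methyl would give a similar step on another aromatic carbon or with a different group elsewhere on the shared core.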